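A few compounds are considered here, and "the series" means these few. Any claim that something is new, unique, unknown or untested is made for them only; others in the source may bear on it.

For the measured compounds named here, compound 2 `COc1ccc(C2CC(c3cc(Cl)c(C)cc3O)=NN2c2ccc(S(N)(=O)=O)cc2)cc1OC` gives 7520 nM in a functional assay on RXF 393 cells (Homo sapiens) for antiproliferative activity, with a stated time of 48 h (on this read-out lower numbers stand for stronger inhibition of growth and higher numbers for weaker inhibition of growth), and stands lowest of the two numbers so far. Going by the values given here, compound 1 `Cc1cc(O)c(C2=NN(c3ccc(S(N)(=O)=O)cc3)C(/C=C/c3ccccc3)C2)cc1Cl` gives 20200 nM in this assay; the only measured step, a 2.7-fold lower number from compound 1 to compound 2 (0.43 log units; beyond the scatter), swaps the whole group on the saturated ring carbon. Compound 3 `COc1ccc(C2CC(c3cc(Cl)c(C)cc3O)=NN2c2ccc(S(N)(=O)=O)cc2)c(OC)c1OC` carries the smaller change (methoxy in place of hydrogen on an aromatic carbon). Among the compounds with values here, no measured step tests an added methoxy on this aromatic ring, so compound 3 is expected to stay within the scatter of compound 2 in this assay, a 1.1-fold lower number from compound 2 to compound 3 (0.03 log units; within the scatter). Compound 3 is estimated at 7000 nM, range 3000 nM to 17000 nM.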

Compound 3, concentration for total growth inhibition: 6020 nM
Compound 3: middle estimate off by 1.2-fold (0.07 log units), on the high side; measured number inside the range.
By their numbers in this assay, from the lowest: compounds 3 and 2 (each within the scatter of the next); then compound 1.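

In this assay, methoxy in place of hydrogen on the aromatic carbon ortho to a large group stays within the scatter (a 1.2-fold lower number from compound 2 to compound 3 (0.10 log units; within the scatter)), so this position tolerates the added methoxy without a clear gain or loss. The 2,3,4-trimethoxyphenyl group also keeps a separation from the 2-phenylethenyl group beyond the scatter (a 3.4-fold lower number from compound 1 to compound 3 (0.53 log units; beyond the scatter)). No measurement at hand explains either result. From the compounds shown here alone, whether an amine or a carboxylic acid on this aromatic carbon would behave like methoxy remains open. Going by these compounds, the shared core is constant across all three compounds, so its contribution also remains open.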